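Methylsulfanyl-pyrimidine carbonitriles with a chloroquinoline tail

The compounds below may be only part of what the source reports. "The series", "measured", "known", "first", "only" and "open" are said of these compounds alone.

Compound 1 `CSc1nc(NCCCCNc2ccnc3cc(Cl)ccc23)c(C#N)c(-c2cccc([N+](=O)[O-])c2)n1` is the reference point of the pair measured so far. In an ADME assay on CCRF-CEM cells (Homo sapiens) for inhibition, read by cell counting (on this read-out higher numbers stand for weaker inhibition and lower numbers for stronger inhibition), compound 1 gives 2100 nM, the lower of the two numbers in hand. Among the compounds with values here, compound 2 `CSc1nc(-c2ccc([N+](=O)[O-])cc2)c(C#N)c(N2CCN(c3ccnc4cc(Cl)ccc34)CC2)n1` shares the core but differs in more than one place, so no single step links the two; in this assay compound 2 gives 156000 nM, and the two values simply show compound 1 at the stronger end of what has been measured.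

Compound 3 `COc1ccc(-c2nc(SC)nc(NCCCCNc3ccnc4cc(Cl)ccc34)c2C#N)cc1` has not yet been measured. It differs from compound 1 in one place: 4-methoxyphenyl in place of 3-nitrophenyl on an aromatic carbon. Within the data shown here, no measured pair shows this exchange alone on this core, so nothing in the data fixes its direction. With only compound 1 as an anchor at 2100 nM, the expectation for the step from compound 1 to compound 3 in this assay is a small one, a 1.4-fold higher number from compound 1 to compound 3 (0.15 log units; within the scatter), not clearly beyond the scatter in either direction. On that basis compound 3 is estimated at 3000 nM in this assay, expected to fall between 800 nM and 12000 nM.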

Compound 3, half-maximal inhibitory concentration: 2700 nM
Estimate against measurement, compound 3: 1.1-fold (0.05 log units) above; the range from low to high includes it.
By their numbers in this assay, from the lowest: compounds 1 and 3 (each within the scatter of the next); then compound 2.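

In this assay, placing 4-methoxyphenyl in place of 3-nitrophenyl on the aromatic carbon next to the ring nitrogen and ortho to a cyano group gives a 1.3-fold higher number from compound 1 to compound 3 (0.11 log units; within the scatter), so compound 1 and compound 3 cannot be told apart on this read-out. Within the data shown here, this is the first single-place step, and it shows that this position can carry either aryl group with the rest of compound 1 held constant and no change beyond the scatter. The exchange alters both the ring substituent and its location on the phenyl ring. The flat result applies to this pair of groups as a whole, and no measured property is available to interpret it.

Nitro and methoxy each appear here at a single location on the phenyl ring, so the effect of the substituent and that of its location remain unseparated. Going by these compounds, whether the same flat result would hold for an unsubstituted phenyl, a phenyl bearing an amine or a carboxylic acid, or a small alkyl group such as methyl directly on this aromatic carbon remains open.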